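The source may report more compounds than this note shows. Statements on the series, on what has been measured and on what is new or still open speak of the compounds shown alone.

Compound 1 `CNC1=CC(=O)C=C(C(C)(C)C)C1=O` gives 10000 nM
Compound 2 `CC(C)(C)C1=CC(=O)C=CC1=O` gives 95000 nM
Compound 3 `CCNC1=CC(=O)C=C(C(C)(C)C)C1=O` gives 30000 nM

These values come from an ADME assay on HaCaT cells (Homo sapiens) for cytotoxicity, read by MTT assay, with a stated time of 72 h; a higher number here means a weaker inhibitor, a lower number a stronger inhibitor. Compound 2 has the highest number of the three. Compound 4 `CCNC1=CC(=O)C(C(C)(C)C)=CC1=O` differs from it in one place: ethylamino in place of hydrogen on a double-bonded ring carbon. This is ethylamino in place of hydrogen on a double-bonded ring carbon. The closest guide is a 3.2-fold lower number from compound 2 to compound 3 (0.50 log units; beyond the scatter), where ethylamino enters at a different ring carbon. Read backwards, a 9.5-fold higher number from compound 1 to compound 2 (0.98 log units; beyond the scatter) points the same way, and a 3.0-fold higher number from compound 1 to compound 3 (0.48 log units; beyond the scatter) shows that the amine chain alone can shift the number. Going by the values given here, no measured pair shows what moving the group along the ring does, so a lower number of similar size is expected. The estimated step is a 3.2-fold lower number from compound 2 to compound 4 (0.50 log units; beyond the scatter). For compound 4 the expected value is 30000 nM, within a range of 10000 nM to 80000 nM.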

Compound 4, half-maximal inhibitory concentration: 75000 nM
Compound 4: middle estimate off by 2.5-fold (0.40 log units), on the low side, and the stated range covers the measured number.
By their numbers in this assay, from the lowest: compound 1; then compound 3; then compounds 4 and 2 (each within the scatter of the next).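

In this assay there is a 1.3-fold lower number from compound 2 to compound 4 (0.10 log units; within the scatter) when ethylamino enters at this ring carbon, so here the added group gives no separation from compound 2. The same group on a different ring carbon gave a 3.2-fold lower number from compound 2 to compound 3 (0.50 log units; beyond the scatter) and did separate, so in these compounds the outcome depends on which ring carbon carries it. Nothing measured here explains that difference. Still open, as far as these compounds go, is whether a longer chain such as butylamino, or a cyclic amine such as morpholine, at this ring carbon would also stay within the scatter of compound 2.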